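This account rests on a few compounds, and the source may have more. Where it says the series, first, only, none or still open, it means among the compounds named here.

Compound 1 `CCCC(=O)N1N=C(c2cc(OC)ccc2N)SC1(C)C` and compound 2 `CCCCC(=O)N1N=C(c2cc(OC)ccc2N)SC1(C)C` share one core and were both tested in an assay on isolated protein for inhibition of Nitric oxide synthase, inducible (Homo sapiens), read by scintillation counting, with a stated time of 30 min, tested at 50 uM; on this read-out higher numbers stand for more inhibition at the one concentration tested (going by the name of the read-out) and lower numbers for less inhibition. In that assay compound 1 gives 91.1% and compound 2 gives 101%. The change between them is methyl in place of hydrogen on a saturated chain carbon, three bonds along the chain from a carbonyl carbon, and it yields a number 9.9 percentage points higher from compound 1 to compound 2 (within the scatter). Compound 3 `CC(=O)N1N=C(c2ccccc2N)SC1(C)C` has a different core, and how the two cores differ is not broken down here. In this assay compound 3 gives 22.9%. Compound 4 `CCC(=O)N1N=C(c2ccccc2N)SC1(C)C` is not yet measured. It differs from compound 3 by methyl in place of hydrogen on a saturated chain carbon bound to a carbonyl carbon, the same kind of change as that from compound 1 to compound 2, though here the place is a saturated chain carbon bound to a carbonyl carbon rather than one three bonds along the chain from a carbonyl carbon. Only a modest step is expected, a number 12.1 percentage points higher from compound 3 to compound 4 (beyond the scatter), resting on the earlier step, a number 9.9 percentage points higher from compound 1 to compound 2 (within the scatter). For compound 4 the estimate is 35%, expected to lie between 15% and 60%.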

Compound 4, a percentage reported as inhibition, at one concentration (the size of the read-out at that concentration, not a potency): 19.2%
For compound 4 the middle estimate is 15.8 percentage points above the measured one; low and high end bracket the measured number.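

In this assay, a step of a number 3.7 percentage points lower from compound 3 to compound 4 (within the scatter) is what methyl in place of hydrogen on a saturated chain carbon bound to a carbonyl carbon gives. Set beside the earlier step on the other core, the change shows no measurable dependence on the core: the same change on two cores in this assay, a number 9.9 percentage points higher (within the scatter) from compound 1 to compound 2 and a number 3.7 percentage points lower (within the scatter) from compound 3 to compound 4, 13.6 percentage points apart, within the scatter of two such steps. This rests on a single pair per core, and the two places on the chain are not the same, so it does not show that the change is without effect on other cores or at other places.

Left open is whether an amine or a carboxylic acid on the acyl chain would shift the number on either core.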